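Changing the carbonyl side chain: compound 2 to compound 3

This account rests on a few compounds, and the source may have more. Where it says the series, first, only, none or still open, it means among the compounds named here.

Measured in a functional assay on A-431 cells (Homo sapiens) for antiproliferative activity, read by sulforhodamine B assay, with a stated time of 72 h (a higher number here means a weaker inhibitor, a lower number a stronger inhibitor), as half-maximal inhibitory concentration:
- compound 1 `COCCNC(=O)Nc1cc2c(Nc3ccc(F)c(Cl)c3)ncnc2cc1O[C@H]1CCOC1` gives 387 nM here
- compound 2 `CCN(CC)CCN(C)C(=O)Nc1cc2c(Nc3ccc(F)c(Cl)c3)ncnc2cc1O[C@H]1CCOC1` gives 481 nM here

Compound 2 at 481 nM sits within the scatter of compound 1 at 387 nM on these numbers. The unmeasured compound 3 `O=C(Nc1cc2c(Nc3ccc(F)c(Cl)c3)ncnc2cc1O[C@H]1CCOC1)N1CCC(N2CCCC2)CC1` differs from compound 2 by this change 4-(pyrrolidin-1-yl)piperidin-1-yl in place of (2-(diethylamino)ethyl)(methyl)amino on a carbonyl carbon in which 4-(pyrrolidin-1-yl)piperidin-1-yl takes the place of (2-(diethylamino)ethyl)(methyl)amino on a carbonyl carbon. Within the data shown here, one measured step bears on this, a 1.2-fold higher number from compound 1 to compound 2 (0.09 log units; within the scatter) at the same kind of carbonyl carbon, and it stays within the scatter. Neither measured compound carries the entering group, so this single step is thin support. In this assay no step beyond the scatter is therefore expected. The estimated 1.1-fold lower number from compound 2 to compound 3 (0.06 log units; within the scatter) is small on this reading. For compound 3 the expected value is 420 nM with an estimated range from 140 nM to 1250 nM for now.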

Compound 3, half-maximal inhibitory concentration: 317 nM
Estimate against measurement, compound 3: 1.3-fold (0.12 log units) above, within the range that was stated.
By their numbers in this assay, from the lowest: compounds 3, 1 and 2 (each within the scatter of the next).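

In this assay, the carbonyl carbon now carries 4-(pyrrolidin-1-yl)piperidin-1-yl, a group with two non-aromatic rings, and the replacement of the open-chain groups gives a 1.5-fold lower number from compound 2 to compound 3 (0.18 log units; within the scatter) and a 1.2-fold lower number from compound 1 to compound 3 (0.09 log units; within the scatter). Across these three compounds, then, a change from an open chain to this ring-bearing group at this position produces no step beyond the scatter, and the read-out does not separate the three side chains. No measurement at hand accounts for these numbers.

Going by these compounds, whether any group on this carbonyl carbon can move the number beyond the scatter remains open. A carboxylic acid on the piperidine ring, or a plain unbranched alkyl chain in place of the whole side chain, would test how far this tolerance extends.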